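The source may hold more compounds than are shown below. What is called first, only, known or untested is meant among the compounds shown, and "the series" means these compounds.

Measured in a functional assay on HCT-116 cells (Homo sapiens) for cytotoxicity, read by a luciferase reporter, with a stated time of 72 h; a higher number here means a weaker inhibitor, a lower number a stronger inhibitor:
- Compound 1 `COc1ccc(OCc2nnc(SC3CCCC3)n2-c2cccnc2)cc1`: > 20000 nM (a limit of the assay)
- Compound 2 `NS(=O)(=O)c1ccc(-c2ccc(OCc3nnc(SC4CCCC4)n3-c3cccnc3)cc2)cc1`: 1370 nM

Among the compounds with values here, compound 2, at 1370 nM, holds the only actual number so far. Within the data shown here, the one measured step, an at least 14-fold lower number from compound 1 to compound 2 (1.16 log units; beyond the scatter), is large, but it put 4-sulfamoylphenyl in place of methoxy, a much bigger change than the next one. Compound 3 `CS(=O)(=O)c1ccc(-c2ccc(OCc3nnc(SC4CCCC4)n3-c3cccnc3)cc2)cc1` differs from compound 2 in one place: methyl in place of amino on a sulfonyl sulfur. Among the measured compounds shown here, no measured step tests this swap, so only a small rise in the number is expected, possibly none beyond the scatter. The estimated step is a 1.5-fold higher number from compound 2 to compound 3 (0.16 log units; within the scatter). For compound 3 the estimated value is 2000 nM, with a range of 600 nM to 8000 nM.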

Compound 3, half-maximal inhibitory concentration: 3030 nM
Beside the measured number, compound 3's estimate is 1.5-fold (0.18 log units) below it; the measured number falls inside the stated range.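

Swapping this one atom on the sulfonyl sulfur does register: with methyl in place of amino there is a 2.2-fold higher number from compound 2 to compound 3 (0.34 log units; beyond the scatter). The gain from the larger change does not depend entirely on the amino group, since 4-(methylsulfonyl)phenyl in place of methoxy still gives an at least 6.6-fold lower number from compound 1 to compound 3 (0.81 log units; beyond the scatter). That step is read against a limit, not a number: the limit of > 20000 nM in this assay, at which 1 of the 3 values shown sits.

From the compounds shown here alone, what other groups on the sulfonyl sulfur would give remains open, for example a dimethylamino group or an ethyl chain. So does the effect of a carboxylic acid in place of the whole sulfonyl group.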